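Isobutyl to Sec-Butyl on the Amine Nitrogen

The compounds below may be only part of what the source reports. "The series", "measured", "known", "first", "only" and "open" are said of these compounds alone.

Compound 1, `COc1cc(/C=C/C(=O)/C=C(/C=C/c2ccc(OC(C)=O)c(OC)c2)NC2CCCCC2)ccc1OC(C)=O`: 89%
Compound 2, `COc1cc(/C=C/C(=O)/C=C(/C=C/c2ccc(OC(C)=O)c(OC)c2)NCC(C)C)ccc1OC(C)=O`: 96%

Of the compounds shown here, two have been measured in a functional assay on Caco-2 cells (Homo sapiens), read by fluorescence, tested at 1 uM; on this read-out higher numbers stand for a weaker effect at the one concentration tested and lower numbers for a stronger effect. Among the measured compounds shown here, compound 2 holds the higher of the two numbers, but the gap to compound 1 is small: the only measured step, a number 7 percentage points higher from compound 1 to compound 2 (within the scatter), arises from isobutyl in place of cyclohexyl on an amine nitrogen and stays within the scatter, so on these numbers the two compounds cannot be told apart.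

Compound 3, `CCC(C)NC(=C\C(=O)/C=C/c1ccc(OC(C)=O)c(OC)c1)/C=C/c1ccc(OC(C)=O)c(OC)c1`, is not yet measured. Compared with compound 2 the change is sec-butyl in place of isobutyl on an amine nitrogen. For the measured compounds named here, only the step from compound 1 to compound 2 bears on this position, and that far larger exchange of the group on the same nitrogen produced nothing beyond the scatter. The expected step is therefore a number 2 percentage points lower from compound 2 to compound 3 (within the scatter), meaning no change beyond the scatter. For compound 3 the estimate is 94%, with a range from 82% to 104%.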

Compound 3, a percentage reported as activity, at one concentration (the size of the read-out at that concentration, not a potency): 95%
For compound 3 the middle estimate is 1 percentage points below the measured one; the range from low to high includes it.
By their numbers in this assay, from the lowest: compounds 1, 3 and 2 (each within the scatter of the next).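

Isobutyl and sec-butyl hold the same atoms joined differently, and that rearrangement on the amine nitrogen gives a number 1 percentage points lower from compound 2 to compound 3 (within the scatter) in this assay, so this read-out does not separate the two groups. The ring comparison agrees: with a number 6 percentage points higher from compound 1 to compound 3 (within the scatter), the step from cyclohexyl to sec-butyl also stays inside the scatter, and a second branched chain now joins isobutyl in matching the cyclohexyl compound. No available evidence offers a reason for this sameness.

Going by these compounds, all three groups on this nitrogen are made only of carbon and hydrogen, so it remains open whether a group of another kind, such as a carboxylic acid or a chain ending in an amine, would shift the number beyond the scatter. A much smaller group such as methyl, or a longer chain such as octyl, also remains an open question at this position.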